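Furan for Methoxyphenyl in a Chalcone Amide Series

The source may hold more compounds than are shown below. What is called first, only, known or untested is meant among the compounds shown, and "the series" means these compounds.

Three chalcone-type amides have been tested in a functional assay on the whole organism (strain albino) for inhibition, with Rattus norvegicus as the target, read by paw edema, with stated times of 30 min and 1 h, at a dose of 100 mg/kg by the oral route; on this read-out higher numbers stand for more inhibition at the one dose given (going by the name of the read-out) and lower numbers for less inhibition. Compound 1 `COc1ccc(/C=C/C(=O)c2ccc(NC(=O)CO[N+](=O)[O-])cc2)cc1` gives 33% in this assay. Compound 2 `O=C(CO[N+](=O)[O-])Nc1ccc(C(=O)/C=C/c2ccco2)cc1` gives 34% in this assay, and compound 3 `COc1ccc(/C=C/C(=O)c2ccc(NC(=O)C(C)Br)cc2)cc1` gives 39% in this assay. The difference between compound 1 and compound 2 is furan-2-yl in place of 4-methoxyphenyl on a double-bonded chain carbon bound to a double-bonded chain carbon, and this change made a step of a number 1 percentage points higher from compound 1 to compound 2 (within the scatter). The cores of compound 1 and compound 3 differ by 1-bromoethyl in place of (nitrooxy)methyl on a carbonyl carbon, which gave a number 6 percentage points higher from compound 1 to compound 3 (within the scatter). All three numbers lie within the scatter of one another, so no order among them can be read.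

The unmeasured compound 4 `CC(Br)C(=O)Nc1ccc(C(=O)/C=C/c2ccco2)cc1` is related to compound 3 by furan-2-yl in place of 4-methoxyphenyl on a double-bonded chain carbon bound to a double-bonded chain carbon, the same change, at the same place, as that between compound 1 and compound 2. Because a number 1 percentage points higher from compound 1 to compound 2 (within the scatter) stayed within the scatter, the expected step is a number 1 percentage points higher from compound 3 to compound 4 (within the scatter), set beside that earlier one. Compound 4 is therefore estimated to give 40% in this assay, most likely between 30% and 50%.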

Compound 4, a percentage reported as inhibition, in the whole organism at one dose (the size of the read-out at that dose, not a potency): 30%
Beside the measured number, compound 4's estimate is 10 percentage points above it, and the stated range covers the measured number.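

The furan-2-yl for 4-methoxyphenyl change, carried to a second core, gave a number 9 percentage points lower from compound 3 to compound 4 (within the scatter) in this assay, and the 1-bromoethyl for (nitrooxy)methyl change, carried likewise, gave a number 4 percentage points lower from compound 2 to compound 4 (within the scatter). For the furan-2-yl change, the two steps cannot be told apart: the same change on two cores in this assay, a number 1 percentage points higher (within the scatter) from compound 1 to compound 2 and a number 9 percentage points lower (within the scatter) from compound 3 to compound 4, 10 percentage points apart, within the scatter of two such steps. The same holds for the 1-bromoethyl change, so the four compounds show neither that these changes carry over to another core with the same step nor that the step depends on the core: the same change on two cores in this assay, a number 6 percentage points higher (within the scatter) from compound 1 to compound 3 and a number 4 percentage points lower (within the scatter) from compound 2 to compound 4, 10 percentage points apart, within the scatter of two such steps.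

With every step inside the scatter, the compounds shown leave open whether either exchanged group matters at all in this assay. Going by these compounds, it also remains open whether an amine or a carboxylic acid in place of 1-bromoethyl, or a longer chain on the carbonyl carbon, would move the inhibition beyond the scatter.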